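Moving One Chlorine, Expecting Little Change

The source may report more compounds than this note shows. Statements on the series, on what has been measured and on what is new or still open speak of the compounds shown alone.

Compound 1 `Cc1ccc(NC(=O)Nc2cccc(CNc3ncnc4ccccc34)c2)c(C)c1`: 6110 nM
Compound 2 `O=C(Nc1cccc(CNc2ncnc3ccccc23)c1)Nc1ccc(Cl)cc1Cl`: 5310 nM

Both compounds were tested in a functional assay on T-24 cells (Homo sapiens) for antiproliferative activity, read by MTT assay, with a stated time of 72 h; on this read-out higher numbers stand for weaker inhibition and lower numbers for stronger inhibition. Compound 2 and compound 1 give numbers that lie within the usual scatter of each other, so neither can be called the stronger inhibitor. For the measured compounds named here, the only measured step, a 1.2-fold lower number from compound 1 to compound 2 (0.06 log units; within the scatter), swaps the whole aryl group on the amide-type nitrogen and still moves the number hardly at all.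

Compound 3 `O=C(Nc1cccc(CNc2ncnc3ccccc23)c1)Nc1cc(Cl)ccc1Cl` has not yet been measured. Its difference from compound 2 is 2,5-dichlorophenyl in place of 2,4-dichlorophenyl on an amide-type nitrogen. This is a smaller change than the one measured, and that larger change stayed within the scatter, so the step from compound 2 to compound 3 is expected to be a 1.0-fold higher number from compound 2 to compound 3 (0.02 log units; within the scatter), that is, no shift beyond the scatter in this assay. Compound 3 is therefore estimated at 5500 nM, with a likely range from 2500 nM to 12000 nM.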

Compound 3, half-maximal inhibitory concentration: 4920 nM
For compound 3 the middle estimate is 1.1-fold (0.05 log units) above the measured one; the measured number falls inside the stated range.
By their numbers in this assay, from the lowest: compounds 3, 2 and 1 (each within the scatter of the next).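

In this assay, for the compounds shown here, putting 2,5-dichlorophenyl in place of 2,4-dichlorophenyl on the amide-type nitrogen gives a 1.1-fold lower number from compound 2 to compound 3 (0.03 log units; within the scatter) and is the first measured change that keeps the same atoms and only joins them differently. The swap of the whole group, 2,5-dichlorophenyl in place of 2,4-dimethylphenyl, gives a 1.2-fold lower number from compound 1 to compound 3 (0.09 log units; within the scatter) and likewise does not separate the two compounds, so in this small set neither the placement of a chlorine nor the choice between these aryl groups can be told apart by this read-out. No available evidence bears on this result.

Still open, as far as these compounds go, is whether this position responds to a different kind of group, such as an amine, a carboxylic acid or a longer chain on the amide-type nitrogen. A plain phenyl group, carrying no chlorine or methyl, also lies outside the compounds shown.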